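Moving the Chloro Substituent on the Sulfonamide Aryl

The source may hold more compounds than are shown below. What is called first, only, known or untested is meant among the compounds shown, and "the series" means these compounds.

Compound 1 `Cc1ccccc1C(=O)NCc1ccc(CNS(=O)(=O)c2ccc(Cl)cc2)cc1` gives 1 nM in an assay on MDA-MB-231 cells for displacement of a labelled ligand from C-X-C chemokine receptor type 4 (Homo sapiens), read by fluorescence and microscopy, with stated times of 10 min and 30 min (on this read-out higher numbers stand for an effect only at larger amounts of compound and lower numbers for an effect already at smaller amounts), the lowest of the three measured numbers. Compound 2 `COc1ccccc1C(=O)NCc1ccc(CNS(=O)(=O)c2ccc(F)cc2)cc1` gives 100 nM and compound 3 `COc1ccccc1C(=O)NCc1ccc(CNS(=O)(=O)c2ccc(Cl)cc2)cc1` gives 1000 nM. The step of a 1000-fold higher number from compound 1 to compound 3 (3.00 log units; beyond the scatter) and the step of a 10-fold higher number from compound 2 to compound 3 (1.00 log units; beyond the scatter) show that the amide aryl and the sulfonamide aryl have each shifted the read-out. Compound 4 `Cc1ccccc1C(=O)NCc1ccc(CNS(=O)(=O)c2ccccc2Cl)cc1` differs from compound 1 by 2-chlorophenyl in place of 4-chlorophenyl on a sulfonyl sulfur. Going by the values given here, no measured pair moves a substituent to another position on the sulfonamide aryl, so neither step applies directly; the only hint is that a change on that ring, as in a 10-fold higher number from compound 2 to compound 3 (1.00 log units; beyond the scatter), has altered the number before. One therefore expects a modest loss, a 10-fold higher number from compound 1 to compound 4 (1.00 log units; beyond the scatter), with wide uncertainty. Compound 4 is estimated at 10 nM, between 1 nM and 300 nM.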

Compound 4, effective concentration (reported as EC, without a stated level of effect): 1000 nM
Compound 4: the middle estimate sits 100-fold (2.00 log units) below what was measured; measured number outside the range, above it.
By their numbers in this assay, from the lowest: compound 1; then compound 2; then compounds 3 and 4 (each within the scatter of the next).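

With the same atoms on both sides, 2-chlorophenyl in place of 4-chlorophenyl on a sulfonyl sulfur gives a 1000-fold higher number from compound 1 to compound 4 (3.00 log units; beyond the scatter). The earlier compounds shown here showed only that the identity of the halogen on this aryl changes the number; this step shows that, on the core of compound 1, where the chloro sits matters as well, and by a large margin. No available evidence accounts for this step. As far as these compounds go, whether a plain phenyl or a pyridyl group on the sulfonyl sulfur would retain the low number of compound 1 remains open, as does the effect of 2-chlorophenyl alongside the methoxy of compound 3.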